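From acetamido to (propylcarbonyl)amino on compound 2

The source may report more compounds than this note shows. Statements on the series, on what has been measured and on what is new or still open speak of the compounds shown alone.

In an ADME assay on microsomes from liver (Homo sapiens) for metabolic stability, read by LC-MS, using NADPH, tested at 1 uM (on this read-out higher numbers stand for a longer-lived compound and lower numbers for a shorter-lived compound), compound 1 (`CCOC(=O)NC/C=C\CN(C)C[C@H]1O[C@@H](n2c(C)nc3c(N)ncnc32)[C@H](O)[C@@H]1O`) gives > 1.5 h as its result, which is a limit of the assay and not a number. Compound 2 (`CC(=O)NC/C=C\CN(C)C[C@H]1O[C@@H](n2cnc3c(N)ncnc32)[C@H](OC(C)=O)[C@@H]1OC(C)=O`) gives > 1.5 h as its result, and this too is a limit and not a number. Within the data shown here, compound 2 therefore has no exact half-life to its name, and the whole record so far is the limit of > 1.5 h in this assay, at which 2 of the 2 values shown sit, with no step between measured compounds to go by. Compound 3 (`CCCC(=O)NC/C=C\CN(C)C[C@H]1O[C@@H](n2cnc3c(N)ncnc32)[C@H](OC(C)=O)[C@@H]1OC(C)=O`) departs from compound 2 through ethyl in place of hydrogen on a saturated chain carbon bound to a carbonyl carbon in the side chain, that is, ethyl in place of hydrogen on a saturated chain carbon bound to a carbonyl carbon, so that acetamido becomes (propylcarbonyl)amino. No shift beyond the usual scatter is expected for this change in this assay when compound 3 is measured. The estimated step is a step that the limit leaves unreadable from compound 2 to compound 3 and is expected to stay within that scatter. For compound 3 the expected half-life is an estimated 1.8 h with an expected range from 0.8 h to 4 h in this measurement.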

Compound 3, half-life: 0.85 h
The estimate for compound 3 lay 2.1-fold (0.33 log units) above the measured number; measured number inside the range.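

Among these compounds, with compound 3, this assay gives for the first time a number rather than a limit, so a change at this saturated chain carbon bound to a carbonyl carbon can now be partly read. Ethyl in place of hydrogen there, which turns acetamido into (propylcarbonyl)amino, comes with an at least 1.7-fold lower number from compound 2 to compound 3 (0.24 log units; that floor lies within the scatter). This is a floor and not a full size, so the change takes the compound off the limit without showing a loss beyond the scatter, and most of the record remains at that limit: the limit of > 1.5 h in this assay, at which 2 of the 3 values shown sit.

From the compounds shown here alone, how far the half-life moves with this change remains open, and so does whether it follows chain length, since only acetamido and (propylcarbonyl)amino can be set side by side here. Neither an intermediate ethyl chain, a longer pentyl chain, a branched isopropyl group nor a terminal amine on the same carbonyl is among the compounds shown, and compound 1 differs from compound 2 and compound 3 in more than one place, so it cannot settle the question.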